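Working notes: compound 2 to compound 3

This account rests on a few compounds, and the source may have more. Where it says the series, first, only, none or still open, it means among the compounds named here.

In a physicochemical assay for solubility, in phosphate buffer, with a stated time of 24 h, at pH 7.4, tested at 100 uM (a lower number here means a less soluble compound, a higher number a more soluble compound), compound 2 `O=C(NCc1ccc(S(=O)(=O)N2CCOCC2)cc1)N1Cc2ccncc2C1` stands highest of the two measured at 59000 nM, while compound 1 `O=C(NCc1ccc(S(=O)(=O)c2cc(F)cc(F)c2)cc1)N1Cc2ccncc2C1` gives 16000 nM. Compound 3 `O=C(NCc1ccc(S(=O)(=O)N2CCC(O)CC2)cc1)N1Cc2ccncc2C1` carries 4-hydroxypiperidin-1-yl in place of morpholin-4-yl on a sulfonyl sulfur. Among the compounds with values here, the only measured step bearing on this is a 3.7-fold higher number from compound 1 to compound 2 (0.57 log units; beyond the scatter). That step replaced an aromatic group with a non-aromatic ring, whereas the present change keeps a six-membered non-aromatic ring, so no step beyond the scatter is expected in this assay. The estimated change is a 1.2-fold lower number from compound 2 to compound 3 (0.07 log units; within the scatter). Compound 3 is expected at 50000 nM, with an estimated range of 25000 nM to 95000 nM.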

Compound 3, solubility: 174000 nM
Estimate against measurement, compound 3: 3.5-fold (0.54 log units) below; measured number above the stated range.
By their numbers in this assay, from the lowest: compound 1; then compound 2; then compound 3.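

In this assay, the group on the sulfonyl sulfur still moves the read-out when the six-membered non-aromatic ring is kept, with a 2.9-fold higher number from compound 2 to compound 3 (0.47 log units; beyond the scatter). Replacing 3,5-difluorophenyl with 4-hydroxypiperidin-1-yl gives an 11-fold higher number from compound 1 to compound 3 (1.04 log units; beyond the scatter), a large step and wider than the earlier change to morpholin-4-yl. No measurement shown accounts for the gain with 4-hydroxypiperidin-1-yl. Still open, as far as these compounds go, is whether the hydroxyl carries the step, which plain piperidin-1-yl or 4-methoxypiperidin-1-yl on the same sulfur would test.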